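Toxicity unchanged at the assay limit for the whole series

A few compounds are considered here, and "the series" means these few. Any claim that something is new, unique, unknown or untested is made for them only; others in the source may bear on it.

Measured compounds:
Compound 1 `Cn1c(-c2ccccc2)cnc1NC(=O)c1ccccc1`: > 100000 nM
Compound 2 `COc1ccc(-c2cnc(NC(=O)c3cccnc3)n2C)cc1`: > 100000 nM
Compound 3 `COc1ccc(-c2cnc(NC(=O)c3ccccn3)n2C)cc1`: > 100000 nM

In a toxicity assay on THP-1 cells (Homo sapiens) for inhibition (on this read-out higher numbers stand for lower toxicity in this test and lower numbers for higher toxicity in this test), compound 3 gives > 100000 nM, which is a limit of the assay and not a number. The same limit applies to compound 1 and to compound 2, so the limit of > 100000 nM in this assay, at which 3 of the 3 values shown sit, shows all three values sitting at the edge of what the assay can report. Going by the values given here, the only measured step, a step that the two limits leave unreadable from compound 2 to compound 3, is therefore unreadable, and nothing shows a step beyond the scatter.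

Compound 4 `COc1ccc(-c2cnc(NC(=O)CCc3ccccc3)n2C)cc1` differs from compound 3 by phenethyl in place of pyridin-2-yl on a carbonyl carbon. Among the compounds with values here, no measured step bears directly on this change; the closest comparison is compound 1, where a carbon-only ring on the carbonyl carbon also sits at the limit in this assay. Compound 4 is therefore expected to stay at the limit as well, with an estimate of 100000 nM (range 50000 nM to 200000 nM). The expected step of a number no higher from compound 3 to compound 4 (the limit leaves the size open) is, in effect, no change beyond the scatter.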

Compound 4, half-maximal cytotoxic concentration: > 100000 nM
Compound 4: a limit, no number; the forecaster's own chance of this, stated with the estimate: 80%; the middle value lies on the limit itself.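

No step can be read from compound 4 to compound 3 or compound 2, as all of them sit at the same limit, which is not a number: the limit of > 100000 nM in this assay, at which 4 of the 4 values shown sit. The compounds shown leave open how far any change on the carbonyl carbon shifts toxicity in this assay.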